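The source may hold more compounds than are shown below. What is called first, only, known or untested is meant among the compounds shown, and "the series" means these compounds.

In a functional assay on CCRF-CEM cells (Homo sapiens) for inhibition (a higher number here means a weaker inhibitor, a lower number a stronger inhibitor), compound 1 `CC(=O)OC[C@H]1O[C@@H](n2cnc3c(-c4ccc(F)cc4)ncnc32)[C@H](OC(C)=O)[C@@H]1OC(C)=O` gives 4000 nM. Compound 2 `Cc1ccc(-c2ncnc3c2ncn3C2O[C@H](CO)[C@@H](O)[C@H]2O)cc1` gives 1500 nM, so compound 1 has the higher number of the two, a gap that lies beyond the scatter and makes compound 1 the weaker inhibitor. The next compound, compound 3 `COc1ccc(-c2ncnc3c2ncn3[C@@H]2O[C@H](COC(C)=O)[C@@H](OC(C)=O)[C@H]2OC(C)=O)cc1`, has not yet been measured. It departs from compound 1 in a single place: methoxy in place of fluoro on an aromatic carbon. This puts methoxy in place of fluoro on an aromatic carbon, para to a large group. For the measured compounds named here, no measured pair of compounds shows this change, so the data offer no direct guide to its effect. In this assay, no step beyond the scatter is expected, in either direction. The estimated step is a 1.1-fold higher number from compound 1 to compound 3 (0.05 log units; within the scatter). For compound 3 the expected value is 4500 nM, with an estimated range from 1500 nM to 13000 nM.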

Compound 3, half-maximal inhibitory concentration: 4300 nM
Compound 3: middle estimate off by 1.0-fold (0.02 log units), on the high side; the range from low to high includes it.
By their numbers in this assay, from the lowest: compound 2; then compounds 1 and 3 (each within the scatter of the next).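

In this assay, for the compounds shown here, the change from 4-fluorophenyl to 4-methoxyphenyl gives a 1.1-fold higher number from compound 1 to compound 3 (0.03 log units; within the scatter) and so provides the first direct reading at this position. On the core of compound 1, at this aromatic carbon para to a large group, the read-out does not separate fluoro from methoxy, even though methoxy brings a hydrogen-bond acceptor that fluoro does not count. No measurement shown here accounts for the two groups reading alike.

The compounds shown leave open whether an amine, a carboxylic acid or a longer alkoxy chain at this place would also stay within the scatter of these two compounds. They also leave open whether the same exchange of fluoro for methoxy would read alike on the core of compound 2.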